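The source may hold more compounds than are shown below. What is called first, only, known or untested is meant among the compounds shown, and "the series" means these compounds.

For the measured compounds named here, in a functional assay on MCF7 cells (Homo sapiens) for inhibition, read by MTT assay, with a stated time of 24 h (a lower number here means a stronger inhibitor, a higher number a weaker inhibitor), compound 2 `CCOC(=O)C1=Cc2ccccc2OC1(OCc1cn(CC(=O)NC2CCCCC2)nn1)C(F)(F)F` gives 12100 nM, the only read value among the three measured compounds. Compound 1 `CCOC(=O)C1=Cc2ccccc2OC1(OCc1cc(-c2ccc(C)cc2)no1)C(F)(F)F` returns > 150000 nM, a limit of the assay. Compound 3 `CCOC(=O)C1=Cc2ccccc2OC1(OCc1cc(-c2ccc(OC)cc2)no1)C(F)(F)F` likewise returns > 150000 nM, a limit. Going by the values given here, the single step between measured compounds, a step that the two limits leave unreadable from compound 1 to compound 3, cannot be sized because of the limit of > 150000 nM in this assay, at which 2 of the 3 values shown sit. Compound 4 `CCOC(=O)C1=Cc2ccccc2OC1(OCc1cn(-c2ccc(C)cc2)nn1)C(F)(F)F` differs from compound 2 by 4-methylphenyl in place of (cyclohexylcarbamoyl)methyl on an aromatic nitrogen. Among the compounds with values here, no measured step covers this change directly; compound 1 and compound 3, each carrying an aryl group on a five-membered ring, both sit at the limit, whereas compound 2, bearing the amide-containing chain, gives a number. For compound 4 a loss is therefore expected, a 5.0-fold higher number from compound 2 to compound 4 (0.70 log units; beyond the scatter), with an estimated 60000 nM and a range from 15000 nM to 200000 nM.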

Compound 4, half-maximal inhibitory concentration: 26700 nM
The estimate for compound 4 lay 2.2-fold (0.35 log units) above the measured number; measured number inside the range.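

In this assay, 4-methylphenyl in place of (cyclohexylcarbamoyl)methyl on the aromatic nitrogen gives a 2.2-fold higher number from compound 2 to compound 4 (0.34 log units; beyond the scatter). A number can therefore still be read at this position without the amide-containing chain, and the entering group has no hydrogen-bond donor or acceptor. Nothing shown gives a cause for this step.

The compounds shown do not separate the share of the amide from that of the cyclohexane ring in the leaving group. Going by these compounds, how a carboxylic acid, a primary amine or a longer alkyl chain on this nitrogen would read remains open.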